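From trifluoromethyl to fluoro in an antiproliferative series

This account rests on a few compounds, and the source may have more. Where it says the series, first, only, none or still open, it means among the compounds named here.

Measured so far in a functional assay on KBVIN cells (Homo sapiens) for antiproliferative activity, read by sulforhodamine B assay, with a stated time of 3 days (a higher number here means that more compound is needed for the effect, a lower number that less compound is needed), are two compounds:

- compound 1 `CCC1=C(O)c2c(oc(-c3cccc(C)c3)cc2=O)C(CC)(CC)C1=O` at 3.69 uM 
- compound 2 `CCC1=C(O)c2c(oc(-c3ccccc3C(F)(F)F)cc2=O)C(CC)(CC)C1=O` at 43.1 uM 

Of these two numbers, compound 2 holds the higher one, and its gap to compound 1 lies beyond the scatter. More of compound 2 is therefore needed for the effect.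

Compound 3 `CCC1=C(O)c2c(oc(-c3ccccc3F)cc2=O)C(CC)(CC)C1=O` keeps the shared core and has not yet been measured in this assay at this stage. It departs from compound 2 by fluoro in place of trifluoromethyl on an aromatic carbon and this amounts to fluoro in place of trifluoromethyl on an aromatic carbon, ortho to a large group.

Going by the values given here, no measured step speaks directly to this change, so any expectation rests on little and the range must stay wide. Compound 1 at 3.69 uM shows that the shared core can read well below compound 2, and a move towards a lower number, beyond the scatter, is expected. The estimated step is a 4.8-fold lower number from compound 2 to compound 3 (0.68 log units; beyond the scatter) in size. The estimate for compound 3 is 9 uM with a range of 2.5 uM to 32 uM expected.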

Compound 3, concentration for half-maximal effect: 3.93 uM
For compound 3 the middle estimate is 2.3-fold (0.36 log units) above the measured one; measured number inside the range.
By their numbers in this assay, from the lowest: compounds 1 and 3 (each within the scatter of the next); then compound 2.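

In this assay, going by these compounds alone, the replacement of trifluoromethyl by fluoro on this aromatic carbon, ortho to a large group, gives an 11-fold lower number from compound 2 to compound 3 (1.04 log units; beyond the scatter), the first direct reading of this change. It shows that the shared core does not by itself set the high number of compound 2, since this single replacement accounts for a large step, and the other step, a 1.1-fold higher number from compound 1 to compound 3 (0.03 log units; within the scatter), places the 2-fluorophenyl of compound 3 level with the 3-methylphenyl of compound 1. Nothing available explains why this one replacement carries so large a step.

The compounds shown leave open how a chloro, methyl or methoxy group on the same aromatic carbon would read, and so whether such groups would stand with fluoro or with trifluoromethyl. They also leave open whether trifluoromethyl carries the same penalty at other places on this aromatic ring, because compound 1 and compound 3 differ from compound 2 in ways that give only this one position a direct comparison.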